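Cyclopentyl enters on the triple-bonded carbon

The source may report more compounds than this note shows. Statements on the series, on what has been measured and on what is new or still open speak of the compounds shown alone.

Values measured in an ADME assay on HepG2 cells (Homo sapiens) for cytotoxicity (a higher number here means that more compound is tolerated, a lower number that less compound is tolerated), for three compounds:
Compound 1 `CC(C)CC#Cc1cc2ncnc(Nc3ccc(OCc4cccc(F)c4)c(Cl)c3)c2s1` gives > 32 uM (a limit)
Compound 2 `CN1CCN(CC#Cc2ccc3ncnc(Nc4ccc(OCc5cccc(F)c5)c(Cl)c4)c3c2)CC1` gives 8.2 uM (a number)
Compound 3 `CCOC(=O)CN(C)CC#Cc1ccc2ncnc(Nc3ccc(OCc4cccc(F)c4)c(Cl)c3)c2c1` gives > 28 uM (a limit)

Compound 3 stands at > 28 uM as a limit, not a number. Compound 2 is the only one of the three with a number. The next compound is compound 4 `Fc1cccc(COc2ccc(Nc3ncnc4ccc(C#CC5CCCC5)cc34)cc2Cl)c1` which keeps the shared core of compound 3 and changes only the group on the triple-bonded carbon: cyclopentyl in place of (((ethoxycarbonyl)methyl)(methyl)amino)methyl on a triple-bonded carbon in short, cyclopentyl in place of (((ethoxycarbonyl)methyl)(methyl)amino)methyl.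

Going by the values given here, one measured step bears on this site. It is an at least 3.4-fold higher number from compound 2 to compound 3 (0.53 log units; beyond the scatter) and it lies beyond the scatter, so a change at this site can move the result in this assay even though that step ends on a limit. It does not cover cyclopentyl, however. The nearest guide is compound 1, whose group on the triple bond is also of carbon only, though its core differs, and it gives > 32 uM as a limit. The expected change is a step that the limit leaves unreadable from compound 3 to compound 4 and no step beyond the scatter is expected in either direction. For compound 4 the estimated value is 30 uM with an expected range from 12 uM to 64 uM and the assay may well report only a limit.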

Compound 4, half-maximal toxic concentration: > 3 uM
Compound 4: no number, only a limit; the forecaster's own chance of this, stated with the estimate: 60%; the middle value is on the limit's open side.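

In this assay compound 4 gives > 3 uM, a limit and not a number. Going by these compounds alone, its steps from compound 2 and from compound 3 therefore cannot be read, and no new step follows from this result. The compounds shown leave open whether cyclopentyl on the triple-bonded carbon moves the result in this assay in either direction, and by how much.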